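A few compounds are considered here, and "the series" means these few. Any claim that something is new, unique, unknown or untested is made for them only; others in the source may bear on it.

Working notes on the series, acid dissociation.

Of the compounds shown here, three carrying the same core have been measured in a physicochemical assay for acid dissociation. Compound 1 `Fc1ccc(Oc2ccc3c(NCCCNCc4ccco4)ccnc3c2)cc1` gives 9.28. Compound 2 `Cc1cc(C)cc(Cc2ccc3c(NCCCNCc4ccco4)ccnc3c2)c1` gives 9.47 in this assay. Compound 3 `c1coc(CNCCCNc2ccnc3cc(-c4cccc5ccccc45)ccc23)c1` gives 9.47 in this assay. All three values sit within the scatter of one another: a number 0.19 log units higher from compound 1 to compound 2 (within the scatter), a number 0.19 log units higher from compound 1 to compound 3 (within the scatter), and no change at the digits printed from compound 2 to compound 3 (within the scatter). Compound 3 therefore stands level with compound 2, with compound 1 within the scatter of both.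

The next step goes from compound 3 to compound 4 `CCC(CC)c1ccc2c(NCCCNCc3ccco3)ccnc2c1`, which is not yet measured in this assay. The change is pentan-3-yl in place of naphthalen-1-yl on an aromatic carbon. For the measured compounds named here, the steps that bear on it are the three swaps at this same aromatic carbon, each of which left this assay unchanged beyond the scatter. Nothing in the measured set suggests the read-out responds to the group at this position, so for this assay a step of about a number 0.02 log units lower from compound 3 to compound 4 (within the scatter) is expected, that is, no change beyond the scatter. Compound 4 is estimated at 9.45, with a range from 9.1 to 9.8.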

Compound 4, acid dissociation constant: 9.47
Estimate against measurement, compound 4: 0.02 log units below; the range from low to high includes it.
By their numbers in this assay, from the lowest: compounds 1, 2, 3 and 4 (each within the scatter of the next).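

In this assay this aromatic carbon now also carries an open-chain group: pentan-3-yl, with no ring and 5 heavy atoms, replaces naphthalen-1-yl, with 2 six-membered aromatic rings and 10 heavy atoms, and the result is no change at the digits printed from compound 3 to compound 4 (within the scatter) for this swap. The same holds against the other two groups, with no change at the digits printed from compound 2 to compound 4 (within the scatter) and a number 0.19 log units higher from compound 1 to compound 4 (within the scatter) in these comparisons, so none of the four compounds goes against a flat read-out at this carbon. No measurement shown accounts for this flat read-out.

As far as these compounds go, whether an amine or a carboxylic acid at this carbon would also leave the read-out within the scatter stays open. So does the effect of any change away from this carbon on the shared core.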